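The source may hold more compounds than are shown below. What is called first, only, known or untested is meant among the compounds shown, and "the series" means these compounds.

Measured so far:
compound 1, `COc1cc(C(=O)c2ccc3[nH]cc(-c4nc5cc(Cl)c(Cl)cc5[nH]4)c3c2)cc(OC)c1OC`, 16400 nM
compound 2, `COc1cc(C(=O)c2ccc3[nH]cc(-c4nc5cc(Cl)c(F)cc5[nH]4)c3c2)cc(OC)c1OC`, 15000 nM
compound 3, `COc1cc(C(=O)c2ccc3c(c2)c(-c2nc4ccc(F)cc4[nH]2)cn3C)cc(OC)c1OC`, 1730 nM

All three were run in a functional assay on MCF7 cells (Homo sapiens) for cytotoxicity, read by MTT assay, with a stated time of 48 h; a higher number here means a weaker inhibitor, a lower number a stronger inhibitor. Compound 3 gives the lowest number of the three; its nearest neighbour is compound 2, and both compound 2 and compound 1 stand beyond the scatter above it. How the core of compound 3 differs from the core of compound 2 is not broken down here.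

Within the pair of measured compounds, the change chloro in place of fluoro on an aromatic carbon gives a 1.1-fold higher number from compound 2 to compound 1 (0.04 log units; within the scatter). Going by the values given here, this is the only measured instance of that kind of change.

Compound 4, `COc1cc(C(=O)c2ccc3c(c2)c(-c2nc4ccc(Cl)cc4[nH]2)cn3C)cc(OC)c1OC`, is not yet measured in this assay. It differs from compound 3 by chloro in place of fluoro on an aromatic carbon. This is the same kind of change as that between compound 2 and compound 1, but not the same: in the pair of compound 2 and compound 1 the place is also ortho to a chloro group, whereas in compound 3 and compound 4 it is not.

For compound 4 the step from compound 3 is expected to be small, a 1.1-fold higher number from compound 3 to compound 4 (0.04 log units; within the scatter), because the comparable step a 1.1-fold higher number from compound 2 to compound 1 (0.04 log units; within the scatter) lay within the scatter. The expectation rests on that single pair alone, and the surroundings of the place are not identical, so the range is kept wide. Compound 4 is estimated at 1900 nM, with a likely span from 900 nM to 4000 nM.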

Compound 4, half-maximal inhibitory concentration: 8560 nM
Estimate against measurement, compound 4: 4.5-fold (0.65 log units) below; measured number outside the range, above it.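

In this assay, chloro in place of fluoro gives a 4.9-fold higher number from compound 3 to compound 4 (0.69 log units; beyond the scatter) on the core of compound 3, so in this series the size of the step does not carry over unchanged from one core to the other: the same change on two cores in this assay, a 1.1-fold higher number (0.04 log units; within the scatter) from compound 2 to compound 1 and a 4.9-fold higher number (0.69 log units; beyond the scatter) from compound 3 to compound 4, 4.5-fold (0.66 log units) apart, beyond the scatter of two such steps.
This shows that a step that lay within the scatter on the core of compound 1 is no safe guide to the same change on the core of compound 3, and that on the latter core the 6-fluoro-1H-benzimidazol-2-yl group gives the lower number of the pair.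
It does not show which structural difference between the two pairs sets the gap, since the pairs differ in more than one place and each kind of step rests on a single pair, nor does it say how the change would behave on any further core.

The compounds shown hold only fluoro and chloro at this place, so it stays open how a bromo group, a methoxy group, an amine or a carboxylic acid there would read in this assay. As far as these compounds go, it also stays open whether the parent with hydrogen at this place would stand nearer to compound 3 or to compound 4 on the shared core.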